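The source may hold more compounds than are shown below. What is called first, only, known or untested is meant among the compounds shown, and "the series" means these compounds.

Compound 2 `O=C(/C=C/c1ccc(OCc2cn(Cc3ccc(Br)cc3)nn2)cc1)c1ccc([N+](=O)[O-])cc1` holds the higher of the two numbers in a functional assay on HepG2 cells (Homo sapiens) for inhibition, read by MTT assay, with a stated time of 48 h, tested at 10 uM (a lower number here means less inhibition of growth, a higher number more inhibition of growth at the concentration tested), with compound 2 at 21% and compound 1 `O=C(/C=C/c1ccc(OCc2cn(Cc3cccc(Br)c3)nn2)cc1)c1ccc([N+](=O)[O-])cc1` at 13%, although the step of a number 8 percentage points higher from compound 1 to compound 2 (within the scatter) lies within the scatter. Compound 3 `O=C(/C=C/c1ccc(OCc2cn(Cc3ccccc3F)nn2)cc1)c1ccc([N+](=O)[O-])cc1` differs from compound 2 by 2-fluorophenyl in place of 4-bromophenyl on a saturated chain carbon bound to an aromatic nitrogen. Among the compounds with values here, the only step that bears on this change, a number 8 percentage points higher from compound 1 to compound 2 (within the scatter), also swaps one ring for another at that place and stays within the scatter, so no step beyond the scatter is expected here. Compound 3 is therefore expected to give 17% in this assay, between 5% and 30%, which means a number 4 percentage points lower from compound 2 to compound 3 (within the scatter).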

Compound 3, percent growth inhibition at one concentration: 22%
The estimate for compound 3 lay 5 percentage points below the measured number; measured number inside the range.
By their numbers in this assay, from the lowest: compounds 1, 2 and 3 (each within the scatter of the next).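

In this assay the 2-fluorophenyl group on a saturated chain carbon bound to an aromatic nitrogen does not separate from either bromophenyl group: the data give a number 1 percentage points higher from compound 2 to compound 3 (within the scatter) and a number 9 percentage points higher from compound 1 to compound 3 (within the scatter) as the two new steps. Changing both the halogen and its ring position at this place therefore produces no step beyond the scatter in these three compounds. No evidence here accounts for this result. On these data alone, whether an amine, a carboxylic acid or a longer chain at this place would give a step beyond the scatter stays open.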